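Swapping the ester group: what stability to expect

This account rests on a few compounds, and the source may have more. Where it says the series, first, only, none or still open, it means among the compounds named here.

Measured compounds:
compound 1, `C[C@@H](O)[C@H]1C(=O)N2C(C(=O)O)=C(S[C@@H]3CN[C@H](C(=O)Nc4cccc(C(=O)OCC(F)(F)F)c4)C3)[C@H](C)[C@H]12`, in an ADME assay for metabolic stability, read by LC-MS, with a stated time of 3 h, at pH 6.5, tested at 50 uM (on this read-out lower numbers stand for a less stable compound and higher numbers for a more stable compound), compound 1 gives > 95%.
compound 2, `C[C@@H](O)[C@H]1C(=O)N2C(C(=O)OCC(F)(F)F)=C(S[C@@H]3CN[C@H](C(=O)Nc4cccc(C(=O)OCC(F)(F)F)c4)C3)[C@H](C)[C@H]12`, in this assay compound 2 gives > 95%.

Compound 1 stands at a limit of this assay; its value is a limit and not a number. Going by the values given here, the one measured step, a step that the two limits leave unreadable from compound 1 to compound 2, cannot be read because of the limit of > 95% in this assay, at which 2 of the 2 values shown sit, so it gives no size in either direction. Compound 3, `CC(C)C(=O)OCOC(=O)c1cccc(NC(=O)[C@@H]2C[C@H](SC3=C(C(=O)O)N4C(=O)[C@H]([C@@H](C)O)[C@H]4[C@H]3C)CN2)c1`, differs from compound 1 by (isopropylcarbonyl)oxy in place of trifluoromethyl on a saturated chain carbon bound to an oxygen next to a carbonyl group. Among the compounds with values here, this change sits on the same oxygen next to a carbonyl group as the step from compound 1 to compound 2, which is the only measured step that bears on it, and that step is unreadable. Within the data shown here, no measured step therefore points to a loss of stability, and none rules one out. On that basis compound 3 is expected to remain near the limit in this assay, with the uncertainty reaching downward. The estimate for compound 3 is 90%, between 65% and 99%. This estimate means a step of a number at least 5 percentage points lower from compound 1 to compound 3 (that floor lies within the scatter), expected to lie within the scatter.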

Compound 3, percent of the compound remaining: > 95%
Compound 3: only a limit was reported; the forecaster's own chance of this, stated with the estimate: 55%; at least 5 percentage points between middle value and limit.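

In this assay compound 3 gives > 95%, which is a limit and not a number. No new step can be read, and compound 1 and compound 3 cannot be compared, because both values sit at the same limit: the limit of > 95% in this assay, at which 3 of the 3 values shown sit.

The compounds shown leave open whether compound 1, compound 2 and compound 3 differ in stability at all.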